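The source may hold more compounds than are shown below. What is called first, only, known or untested is meant among the compounds shown, and "the series" means these compounds.

Measured so far in a functional assay on MCF-10A cells (Homo sapiens) for antiproliferative activity, with a stated time of 48 h; on this read-out higher numbers stand for an effect only at larger amounts of compound and lower numbers for an effect already at smaller amounts:

Compound 1 `COc1ccc2nc(C)cc(SCc3ccc(F)cc3)c2c1`: 50500 nM
Compound 2 `COc1ccc2nc(C)cc(SCc3ccccc3)c2c1`: 37100 nM
Compound 3 `COc1ccc2nc(C)cc(NCc3cccc(F)c3)c2c1`: 14700 nM

Within this set, fluoro in place of hydrogen on an aromatic carbon has been measured once, as fluoro in place of hydrogen on an aromatic carbon, and gave a 1.4-fold higher number from compound 2 to compound 1 (0.13 log units; within the scatter). Compound 3 stands apart from compounds 1 and 2 in more than one place; the difference between the two cores is not broken down here. Compound 3 gives the lowest number of the three, and its distance to compound 2 and to compound 1 lies beyond the scatter in each case.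

Compound 4 `COc1ccc2nc(C)cc(NCc3ccc(F)c(F)c3)c2c1` carries the same kind of change relative to compound 3, as fluoro in place of hydrogen on an aromatic carbon. The place differs from the earlier case in that the entering fluoro sits ortho to a fluoro group, so the two changes are of the same kind rather than the same. Given that the earlier case gave a 1.4-fold higher number from compound 2 to compound 1 (0.13 log units; within the scatter), a step of similar size is expected here, namely a 1.2-fold higher number from compound 3 to compound 4 (0.06 log units; within the scatter). For compound 4 the estimate in this assay is 17000 nM, expected to fall between 8500 nM and 34000 nM.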

Compound 4, half-maximal effective concentration: 12000 nM
Beside the measured number, compound 4's estimate is 1.4-fold (0.15 log units) above it; the range from low to high includes it.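

In this assay, fluoro in place of hydrogen on the core of compound 3 gives a 1.2-fold lower number from compound 3 to compound 4 (0.09 log units; within the scatter), a step that stays within the usual scatter. Set beside the earlier step, the change carries from one core to the other without a difference that can be told from scatter: the same change on two cores in this assay, a 1.4-fold higher number (0.13 log units; within the scatter) from compound 2 to compound 1 and a 1.2-fold lower number (0.09 log units; within the scatter) from compound 3 to compound 4, 1.7-fold (0.22 log units) apart, within the scatter of two such steps. Going by these compounds alone, this does not show that the change is without any effect or that it behaves alike on every core of the series, since it rests on only two pairs, and in compound 4 the entering fluoro sits ortho to a fluoro group, so the two steps are of the same kind rather than the same.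

From the compounds shown here alone, whether a chloro, a trifluoromethyl or a nitrile in place of this fluoro would give a step beyond the scatter stays open. Also open, going by these compounds, is what a longer chain, an amine or a carboxylic acid would do on either core.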